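Removing the amine methyl on the way to compound 3

This account rests on a few compounds, and the source may have more. Where it says the series, first, only, none or still open, it means among the compounds named here.

compound 1 `COc1cc2c(cc1N1C[C@@H](C)N[C@@H](C)C1)N(C(=O)c1ccc(-c3ccc(C(C)=O)cc3C)cc1)CC2`: 3.16 nM
compound 2 `COc1cc2c(cc1N1C[C@@H](C)N(C)[C@@H](C)C1)N(C(=O)c1ccc(-c3ccc(-c4noc(C)n4)cc3C)cc1)CC2`: 5.01 nM

In an assay on isolated protein for binding affinity to 5-hydroxytryptamine receptor 1B (Homo sapiens) (a lower number here means a stronger inhibitor, a higher number a weaker inhibitor), compound 1 gives 3.16 nM, and compound 2 gives 5.01 nM. Compound 2 carries the higher of the two numbers, but compound 1 sits within the scatter of it, so the two cannot be put in order. Compound 1 and compound 2 differ in two places at once, so no single step can be read from them. Compound 3 `COc1cc2c(cc1N1C[C@@H](C)N[C@@H](C)C1)N(C(=O)c1ccc(-c3ccc(-c4noc(C)n4)cc3C)cc1)CC2` keeps the rest of compound 2 and alters only the ring amine: hydrogen in place of methyl on an amine nitrogen in a ring. Within the data shown here, no measured pair isolates this change. The step of a 1.3-fold lower number from compound 2 to compound 3 (0.10 log units; within the scatter) is expected to stay within the scatter, in either direction. Compound 3 is therefore estimated at 4 nM, with a range from 1.5 nM to 12 nM.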

Compound 3, inhibition constant: 3.16 nM
Compound 3: middle estimate off by 1.3-fold (0.10 log units), on the high side; the measured number falls inside the stated range.
By their numbers in this assay, from the lowest: compounds 1, 3 and 2 (each within the scatter of the next).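

In this assay, among these compounds, hydrogen in place of methyl on the ring amine nitrogen, taking 3,4,5-trimethylpiperazin-1-yl to 3,5-dimethylpiperazin-1-yl, gives a 1.6-fold lower number from compound 2 to compound 3 (0.20 log units; within the scatter) and so provides the first single-place reading at this position, one that does not separate the two compounds. With hydrogen on that nitrogen, 5-methyl-1,2,4-oxadiazol-3-yl in place of acetyl on an aromatic carbon gives no change at the digits printed from compound 1 to compound 3 (within the scatter) and likewise leaves the two compounds unseparated. No measurement shown offers an explanation for either result. The compounds shown leave open whether an ethyl or acetyl group on the ring amine nitrogen would stay within the scatter. They also leave open what hydrogen in place of each methyl group on the two ring atoms that bear one would do.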